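A few compounds are considered here, and "the series" means these few. Any claim that something is new, unique, unknown or untested is made for them only; others in the source may bear on it.

Series so far, growth inhibition at one concentration:
- compound 1 `O=C1Nc2ccc(F)cc2/C1=N/NC(=S)Nc1ccccc1`: 10%
- compound 2 `O=C1Nc2ccc(F)cc2/C1=N/NC(=S)Nc1ccccc1F`: 20%
- compound 3 `O=C1Nc2ccc(F)cc2/C1=N/NC(=S)Nc1cccc(F)c1`: 15%

In a functional assay on the whole organism for inhibition, with Lemna aequinoctialis as the target, with a stated time of 7 days, tested at 5 ug/mL (a lower number here means less inhibition of growth, a higher number more inhibition of growth at the concentration tested), compound 3 gives 15%, a number that cannot be separated from those of the other two compounds. The next compound is compound 4 `O=C1Nc2ccc(F)cc2/C1=N/NC(=S)Nc1c(F)cccc1F`, with 2,6-difluorophenyl in place of 3-fluorophenyl on an amide-type nitrogen.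

Among the compounds with values here, three measured steps bear on this change. Adding a single fluoro to the phenyl gave a number 10 percentage points higher from compound 1 to compound 2 (within the scatter) and a number 5 percentage points higher from compound 1 to compound 3 (within the scatter). Exchanging 2-fluorophenyl for 3-fluorophenyl gave a number 5 percentage points lower from compound 2 to compound 3 (within the scatter). All three are small and lie within the scatter, so none of them sets a direction. Within the data shown here, no measured compound carries 2,6-difluorophenyl, so the effect of a second fluoro remains untested.

The expectation is therefore no shift beyond the scatter in this assay. The expected change is a number 5 percentage points higher from compound 3 to compound 4 (within the scatter), which is only a slight lean taken from the small steps seen so far. Compound 4 is estimated at 20%, with an expected range of 5% to 35%.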

Compound 4, percent growth inhibition at one concentration: 0%
Compound 4: the middle estimate sits 20 percentage points above what was measured, outside the stated range (below it).
By their numbers in this assay, from the lowest: compounds 4, 1, 3 and 2 (each within the scatter of the next, the first and the last beyond it).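

In this assay, within the data shown here, the steps to compound 4 are the first to pass the scatter: a number 15 percentage points lower from compound 3 to compound 4 (beyond the scatter) and a number 20 percentage points lower from compound 2 to compound 4 (beyond the scatter). Against the unsubstituted phenyl the picture is different, with a number 10 percentage points lower from compound 1 to compound 4 (within the scatter), so the 2,6-difluorophenyl group separates from the two monofluorinated phenyl compounds but not from the parent phenyl compound. Fluoro in place of hydrogen on this phenyl ring therefore has no constant effect, and its outcome depends on the ring it is added to: the same change on two cores in this assay, a number 5 percentage points higher (within the scatter) from compound 1 to compound 3 and a number 20 percentage points lower (beyond the scatter) from compound 2 to compound 4, 25 percentage points apart, beyond the scatter of two such steps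

The compounds shown do not separate a general effect of two flanking substituents from something specific to fluoro, so 2,6-dichlorophenyl or 2,6-dimethylphenyl on the same amide-type nitrogen would be the informative comparison. Also open, going by these compounds, is whether any group on this nitrogen lifts growth inhibition clearly beyond that of compound 2, for instance a 4-aminophenyl, a 4-carboxyphenyl or a benzyl group, since all four compounds are read at a single concentration and their numbers stay in a narrow band.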